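The compounds below may be only part of what the source reports. "The series", "measured", "known", "first", "only" and "open" are said of these compounds alone.

Measured compounds in a functional assay on HepG2 cells (Homo sapiens) for antiproliferative activity, read by CCK-8 assay, with a stated time of 72 h; a lower number here means a stronger inhibitor, a higher number a weaker inhibitor:
compound 1 `COc1cccc(C(=O)Nc2cccc(-c3oc4cc(-c5ccc(F)cc5)ccc4c(=O)c3O)c2)c1` gives 9950 nM
compound 2 `CCc1ccc(C(=O)Nc2cccc(-c3oc4cc(-c5ccc(F)cc5)ccc4c(=O)c3O)c2)cc1` gives 20600 nM

Compound 2 holds the highest of the two numbers; its nearest neighbour is compound 1, and the step of a 2.1-fold higher number from compound 1 to compound 2 (0.32 log units; beyond the scatter) lies beyond the scatter. Compound 3 `COc1cc(OC)cc(C(=O)Nc2cccc(-c3oc4cc(-c5ccc(F)cc5)ccc4c(=O)c3O)c2)c1` carries 3,5-dimethoxyphenyl in place of 4-ethylphenyl on a carbonyl carbon. For the measured compounds named here, only the step from compound 1 to compound 2 bears on it, and it ran in the opposite direction, so a modest move back toward compound 1 is expected. The expected step is a 2.1-fold lower number from compound 2 to compound 3 (0.31 log units; beyond the scatter). Compound 3 is estimated at 10000 nM, with a range from 4000 nM to 30000 nM.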

Compound 3, half-maximal inhibitory concentration: 23500 nM
Compound 3: middle estimate off by 2.4-fold (0.37 log units), on the low side; low and high end bracket the measured number.
By their numbers in this assay, from the lowest: compound 1; then compounds 2 and 3 (each within the scatter of the next).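

In this assay, 3,5-dimethoxyphenyl in place of 4-ethylphenyl on the carbonyl carbon gives a 1.1-fold higher number from compound 2 to compound 3 (0.06 log units; within the scatter) and so does not separate these two aryl groups. A second methoxy in place of hydrogen on an aromatic carbon gives a 2.4-fold higher number from compound 1 to compound 3 (0.37 log units; beyond the scatter) as a modest weakening, so on this amide the added methoxy does not help. No measurement on hand accounts for either step.

Still open, on these data alone, is whether an amine or a carboxylic acid on this aryl ring would bring the number below that of compound 1, and how the unsubstituted phenyl compares.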